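The compounds below may be only part of what the source reports. "The series", "measured", "known", "first", "only" and "open" are said of these compounds alone.

Three compounds share one core and differ only in the groups attached to it. In a functional assay on HL-60 cells (Homo sapiens) for inhibition, read by MTT assay, with a stated time of 72 h (a lower number here means a stronger inhibitor, a higher number a weaker inhibitor), compound 1 `Cc1nc(-c2ccccc2)c(C(=O)N2CCN(c3ccccc3Cl)CC2)o1` gives 124 nM. Compound 2 `Cc1nc(-c2ccccc2)c(C(=O)N2CCN(c3ccc(C(F)(F)F)cc3)CC2)o1` reaches only the limit of the assay, > 1000 nM, so for it no number is known. Compound 3 `COc1cc(OC)cc(N2CCN(C(=O)c3oc(C)nc3-c3ccccc3F)CC2)c1` gives 10.3 nM, the lowest of the two numbers seen, with compound 1 standing at a higher number beyond the scatter.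

Among the measured compounds shown here, the one measured step, an at least 8.0-fold higher number from compound 1 to compound 2 (0.90 log units; beyond the scatter), changes the ring on the amine nitrogen of the core, which stays the same between compound 3 and compound 4. Compound 4 `COc1cc(OC)cc(N2CCN(C(=O)c3oc(C)nc3-c3ccccc3)CC2)c1` differs from compound 3 in one place: hydrogen in place of fluoro on an aromatic carbon. For the measured compounds named here, no measured step touches this ring, so there is no direct guide in these data for the size or direction of the step. With only a hydrogen replacing fluoro on an aromatic carbon, the expectation is a step that stays within the usual scatter.

Compound 4 is therefore expected to give 15 nM in this assay, within a range from 5 nM to 50 nM. The expected step is a 1.5-fold higher number from compound 3 to compound 4 (0.16 log units; within the scatter), which would lie within the scatter.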

Compound 4, half-maximal inhibitory concentration: 19.2 nM
For compound 4 the middle estimate is 1.3-fold (0.11 log units) below the measured one, and the stated range covers the measured number.
By their numbers in this assay, from the lowest: compounds 3 and 4 (each within the scatter of the next); then compound 1. At a limit, above all of these: compound 2.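

In this assay, the step of a 1.9-fold higher number from compound 3 to compound 4 (0.27 log units; within the scatter) stays within the scatter, so at this place, ortho to a large group, fluoro and hydrogen cannot be told apart. The ring on the amine nitrogen counts for more in these compounds: 3,5-dimethoxyphenyl in place of 2-chlorophenyl gives a 6.5-fold lower number from compound 1 to compound 4 (0.81 log units; beyond the scatter), a step beyond the scatter. With 3,5-dimethoxyphenyl in place of 4-(trifluoromethyl)phenyl, the step of an at least 52-fold lower number from compound 2 to compound 4 (1.71 log units; beyond the scatter) is a bound and not an exact size, since compound 2 stands at a limit: the limit of > 1000 nM in this assay, at which 1 of the 4 values shown sits.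

Only fluoro and hydrogen are shown at this place, so it remains open whether a nitrile or an amine there would shift the number. As far as these compounds go, it is also open whether a single methoxy group on the nitrogen-bound ring would be enough.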